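The source may hold more compounds than are shown below. What is called first, only, known or untested is meant among the compounds shown, and "the series" means these compounds.

Measured in a functional assay on cells (Platelet, Homo sapiens) for inhibition; on this read-out lower numbers stand for stronger inhibition and higher numbers for weaker inhibition:
- Compound 1 `CCCOC(=O)c1ccc(-c2nn(Cc3ccccc3)c3ccccc23)cc1`: > 10000 nM
- Compound 2 `CCNC(=O)c1ccc(-c2nn(Cc3ccccc3)c3ccccc23)cc1`: 5640 nM

The entry for compound 1 is a limit of the assay, not a number. For the measured compounds named here, that makes compound 2, at 5640 nM, the only true number so far. Going by the values given here, the series therefore offers no real ranking yet, and the one comparison available is capped by the limit of > 10000 nM in this assay, at which 1 of the 2 values shown sits.

Compound 3 `CCCNC(=O)c1ccc(-c2nn(Cc3ccccc3)c3ccccc23)cc1` extends the amide chain of compound 2, ethylamino to propylamino: methyl in place of hydrogen on a saturated chain carbon, two bonds along the chain from an amide-type nitrogen. In words, this is methyl in place of hydrogen on a saturated chain carbon, two bonds along the chain from an amide-type nitrogen.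

Among the compounds with values here, the only measured step is an at least 1.7-fold lower number from compound 1 to compound 2 (0.24 log units; that floor lies within the scatter). It changes a different group and stays within the scatter, so it gives no size for a chain extension. With so little to go on, the expected step is a 1.1-fold lower number from compound 2 to compound 3 (0.05 log units; within the scatter), which means no expected change beyond the scatter. For compound 3 the estimated value is 5000 nM, with an expected range of 2000 nM to 12000 nM.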

Compound 3, half-maximal inhibitory concentration: > 10000 nM
Compound 3 gave a limit, no number; the forecaster's own chance of this, stated with the estimate: 25%; middle value at least 2.0-fold (0.30 log units) from the limit.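

In this assay compound 3 gives > 10000 nM, which is a limit of the assay and not a number. From the compounds shown here alone, the added methyl on the amide chain therefore gives no sign of stronger inhibition: the record is an at least 1.7-fold higher number from compound 2 to compound 3 (0.24 log units; that floor lies within the scatter), and the true size of that step remains unknown. The step between compound 1 and compound 3 cannot be read, and most of the series now sits at the same ceiling: the limit of > 10000 nM in this assay, at which 2 of the 3 values shown sit.

For the compounds shown here, compound 2 remains the only compound with a true number, so the trend along this chain rests on a single measured point. Still open, going by these compounds, is whether a shorter group on the amide nitrogen, such as methylamino, or a ring, such as cyclopropylamino, would give stronger inhibition or at least a second true number.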